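The compounds below may be only part of what the source reports. "The series", "measured", "known", "first", "only" and "open" are said of these compounds alone.

Two compounds in the series carry numbers. In a functional assay on HT-29 cells (Homo sapiens) for inhibition, read by sulforhodamine B assay, with a stated time of 48 h (a higher number here means a weaker inhibitor of growth, a lower number a stronger inhibitor of growth), compound 2 `COc1cc(C)cc(-c2nn(CC#N)cc2-c2ccnc(-c3ccc(N(C)C)cc3)c2)c1` gives 481 nM, the lowest of the two; compound 1 `Cc1cc(O)cc(-c2nn(CC#N)cc2-c2ccnc(-c3ccc(Oc4ccccc4)cc3)c2)c1` gives 1830 nM, a gap beyond the scatter. Compound 3 `Cc1cc(O)cc(-c2nn(CC#N)cc2-c2ccnc(-c3ccc(N(C)C)cc3)c2)c1` is not yet measured. It differs from compound 2 by hydrogen in place of methyl on an oxygen on an aromatic ring, the same difference, cut one bond further out, reading methoxy to hydroxy. Among the measured compounds shown here, no measured pair shows this change on its own, so its size cannot be read from the data. From compound 2 a step of a 1.2-fold higher number from compound 2 to compound 3 (0.10 log units; within the scatter) is expected, within or near the scatter, with no firm direction. Compound 3 is estimated at 600 nM in this assay, with a range of 200 nM to 2000 nM.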

Compound 3, concentration for 50% growth inhibition: 4650 nM
For compound 3 the middle estimate is 7.8-fold (0.89 log units) below the measured one; the whole stated range lies below it.
By their numbers in this assay, from the lowest: compound 2; then compound 1; then compound 3.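

In this assay, the methoxy group on the aromatic ring matters: reading methoxy to hydroxy gives a 9.7-fold higher number from compound 2 to compound 3 (0.99 log units; beyond the scatter) with dimethylamino held constant. With hydroxy held constant, dimethylamino in place of phenoxy gives a 2.5-fold higher number from compound 1 to compound 3 (0.41 log units; beyond the scatter) and so favours phenoxy, a change that the two earlier compounds, differing in two places, could not separate. No measurement at hand accounts for the size of either step. As far as these compounds go, whether methoxy gives a similar gain alongside phenoxy remains open, as does the effect of an ethoxy group or an amine at this oxygen-bearing position.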